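Methyl in Place of Trifluoromethyl: a Step from Compound 1

A few compounds are considered here, and "the series" means these few. Any claim that something is new, unique, unknown or untested is made for them only; others in the source may bear on it.

Compound 1 `O=C(O)CCCCCCC(=O)Nc1ccc(C2=C(c3ccc(O)cc3)C3CC(S(=O)(=O)Oc4ccccc4C(F)(F)F)C2O3)cc1` gives > 100000 nM in this study.
Compound 2 `O=S(=O)(Oc1ccccc1)[C@H]1C[C@H]2O[C@@H]1C(c1ccc(O)cc1)=C2c1ccc(O)cc1` gives > 100000 nM.
Compound 3 `O=C(O)CCCCCCC(=O)Nc1cccc(OS(=O)(=O)C2CC3OC2C(c2ccc(O)cc2)=C3c2ccc(O)cc2)c1` gives > 100000 nM.

In a functional assay on DU-145 cells (Homo sapiens) for inhibition, read by MTT assay, with a stated time of 72 h (on this read-out higher numbers stand for weaker inhibition and lower numbers for stronger inhibition), compound 1 reaches only the limit of the measurement, so its value is not a number but the edge of what the read-out reports. Compound 2 likewise sits at the limit in this assay. Compound 3 also gives only a limit in this assay. Within the data shown here, compound 1 therefore stands nowhere distinct among the three: every value shown is the same limit, as the evidence states, (the limit of > 100000 nM in this assay, at which 3 of the 3 values shown sit), and no step between measured compounds can be drawn from them.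

Compound 4 `Cc1ccccc1OS(=O)(=O)C1CC2OC1C(c1ccc(NC(=O)CCCCCCC(=O)O)cc1)=C2c1ccc(O)cc1` differs from compound 1 in one place: methyl in place of trifluoromethyl on an aromatic carbon. Among the measured compounds shown here, no measured pair in this assay covers a change of this kind, so there is no step of known size to lean on. Given that all three measured compounds sit at the limit, the step is expected to be none beyond the scatter, and the most likely outcome is that compound 4 again returns only a limit. The expected step is a step that the limit leaves unreadable from compound 1 to compound 4. Compound 4 is estimated at 150000 nM in this assay, within a range from 30000 nM to 1000000 nM, with a high chance that only a limit is reported.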

Compound 4, half-maximal inhibitory concentration: > 100000 nM
Compound 4 gave a limit, no number; the forecaster's own chance of this, stated with the estimate: 85%; the middle value lies beyond the limit too.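

In this assay compound 4 gives > 100000 nM, which is a limit and not a number. Compound 1 also stands at a limit, so no step can be read from compound 1 to compound 4: the limit of > 100000 nM in this assay, at which 4 of the 4 values shown sit. Going by these compounds, with no number among the four compounds, how methyl and trifluoromethyl compare at this place remains open.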